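Hydroxy for hydrogen on the ring-bound chain carbon

The source may hold more compounds than are shown below. What is called first, only, known or untested is meant among the compounds shown, and "the series" means these compounds.

Among the compounds with values here, compound 1 `CCCCCCCCCCCC(=O)NCC(=O)N[C@@H]1[C@@H](O)[C@H](O)[C@@H](Nc2ncnc3[nH]cnc23)O[C@H]1C` is the only member of the series with a number in a functional assay on L1210 cells (Mus musculus) for inhibition, with a stated time of 3 h; on this read-out higher numbers stand for an effect only at larger amounts of compound and lower numbers for an effect already at smaller amounts: compound 1 gives 18 uM. Compound 2 `CCCCCCCCCCCCCCCCC(NC(C)=O)C(=O)N[C@@H]1[C@@H](O)[C@H](O)[C@@H](Nc2ncnc3[nH]cnc23)O[C@H]1C` reaches only a limit in this assay, > 1000 uM, which is the limit of > 1000 uM in this assay, at which 1 of the 2 values shown sits. Compound 3 `CCCCCCCCCCCC(=O)NCC(=O)N[C@@H]1[C@@H](O)[C@H](O)[C@@H](Nc2ncnc3[nH]cnc23)O[C@H]1CO` differs from compound 1 by hydroxy in place of hydrogen on a saturated chain carbon bound to a saturated ring carbon. Within the data shown here, no measured pair isolates such a change, so the step in this assay is expected to stay within the scatter, with no clear direction, a 1.1-fold higher number from compound 1 to compound 3 (0.05 log units; within the scatter). Compound 3 is accordingly estimated at 20 uM, between 5 uM and 80 uM.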

Compound 3, concentration for half-maximal effect: 5.5 uM
Beside the measured number, compound 3's estimate is 3.6-fold (0.56 log units) above it; the measured number falls inside the stated range.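

Hydroxy in place of hydrogen on a saturated chain carbon bound to a saturated ring carbon gives a 3.3-fold lower number from compound 1 to compound 3 (0.51 log units; beyond the scatter) in this assay and so shows that this position is not silent: the methyl to hydroxymethyl change, though modest, lies beyond the scatter. This rests on one pair, and nothing measured here gives a reason for the step. From the compounds shown here alone, whether an amine or a methoxy group on the same carbon would go further in the same direction stays open, as does the effect of a carboxylic acid there.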